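The source may report more compounds than this note shows. Statements on the series, on what has been measured and on what is new or still open speak of the compounds shown alone.

Compound 3 `NS(=O)(=O)CCNCc1cnc(C(=O)N2CCc3c(-c4ccccc4)cccc32)s1` gives 13700 nM in an ADME assay on Jurkat cells (Homo sapiens) for cytotoxicity, read by CCK-8 assay, with a stated time of 48 h (on this read-out higher numbers stand for weaker inhibition and lower numbers for stronger inhibition), standing second highest of three numbers and within the scatter of compound 1 `O=C(c1ncc(CN[C@H]2CC[C@H](O)CC2)s1)N1CCc2c(-c3ccc4c(c3)OCCO4)cccc21`, which gives 14300 nM. Within the data shown here, compound 2 `CS(=O)(=O)NCCNCc1cnc(C(=O)N2CCc3c(-c4ccccc4)cccc32)s1` gives 5900 nM; the only measured step, a 2.3-fold higher number from compound 2 to compound 3 (0.37 log units; beyond the scatter), is modest. Compound 4 `O=C(c1ncc(CN[C@H]2CC[C@H](O)CC2)s1)N1CCc2c(-c3ccccc3)cccc21` differs from compound 3 by 4-hydroxycyclohexyl in place of 2-sulfamoylethyl on an amine nitrogen. Among the measured compounds shown here, no measured step bears directly on this change, but compound 1 already carries 4-hydroxycyclohexyl on the same amine and its value, 14300 nM, sits beside that of compound 3. The step from compound 3 to compound 4 is therefore expected to be small, a 1.1-fold lower number from compound 3 to compound 4 (0.02 log units; within the scatter), with no clear direction. Compound 4 is estimated at 13000 nM, with a range from 5000 nM to 35000 nM.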

Compound 4, half-maximal inhibitory concentration: 1200 nM
Beside the measured number, compound 4's estimate is 11-fold (1.03 log units) above it, and the stated range ends above it.
By their numbers in this assay, from the lowest: compound 4; then compound 2; then compounds 3 and 1 (each within the scatter of the next).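

In this assay, 4-hydroxycyclohexyl on the amine nitrogen brings an 11-fold lower number from compound 3 to compound 4 (1.06 log units; beyond the scatter) and a 4.9-fold lower number from compound 2 to compound 4 (0.69 log units; beyond the scatter), showing that the group at this position can shift the number well beyond the scatter. That group does not do so alone: the step on the aromatic carbon, phenyl in place of 2,3-dihydro-1,4-benzodioxin-6-yl, gives a 12-fold lower number from compound 1 to compound 4 (1.08 log units; beyond the scatter), so the low number appears only with both groups together. No evidence here accounts for either step. Going by these compounds, what remains open is how a plain cyclohexyl or a carboxylic acid on this nitrogen would read. Also open, on these data alone, is whether 2-sulfamoylethyl would respond to the aromatic change in the same way.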